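Chloro to Trifluoromethyl: What to Expect for Compound 4

This account rests on a few compounds, and the source may have more. Where it says the series, first, only, none or still open, it means among the compounds named here.

Compound 1, `O=C1C(=O)N(CN2CCN(c3ccnc4cc(Cl)ccc34)CC2)c2cccc(Cl)c21`: 39100 nM
Compound 2, `O=C1C(=O)N(CN2CCN(c3ccnc4cc(C(F)(F)F)ccc34)CC2)c2cccc(Cl)c21`: 16900 nM
Compound 3, `NC(=S)N/N=C1/C(=O)N(CN2CCN(c3ccnc4cc(Cl)ccc34)CC2)c2cccc(Cl)c21`: 57500 nM

All three were tested in a functional assay on MCF7 cells (Homo sapiens) for cytotoxicity, read by sulforhodamine B assay, with a stated time of 48 h; a lower number here means a stronger inhibitor of growth, a higher number a weaker inhibitor of growth. Compound 1 and compound 2 share one core and differ only at one aromatic carbon, where the change trifluoromethyl in place of chloro on an aromatic carbon was made. That single swap gave a 2.3-fold lower number from compound 1 to compound 2 (0.36 log units; beyond the scatter), so compound 2 reads as the stronger growth inhibitor of the pair.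

Compound 3 carries a different core; the difference between the core of compound 3 and that of compound 1 is not broken down here. In this assay compound 3 gives 57500 nM, a number that sits within the usual scatter of the value for compound 1, while the number for compound 2 lies beyond the scatter below it.

Compound 4, `NC(=S)N/N=C1/C(=O)N(CN2CCN(c3ccnc4cc(C(F)(F)F)ccc34)CC2)c2cccc(Cl)c21`, has not yet been measured. It is compound 3 with the change (trifluoromethyl in place of chloro on an aromatic carbon), the same change that turned compound 1 into compound 2, at a place described in identical words. If the core of compound 3 responds as the core of compound 1 did, the expected step is a 2.3-fold lower number from compound 3 to compound 4 (0.36 log units; beyond the scatter), resting on the step of a 2.3-fold lower number from compound 1 to compound 2 (0.36 log units; beyond the scatter) seen for compound 2. Going by the values given here, on that basis compound 4 is estimated to give 25000 nM in this assay, with a likely range from 11000 nM to 60000 nM; with only one prior example of this change, the range is kept wide.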

Compound 4, concentration for 50% growth inhibition: 21600 nM
Beside the measured number, compound 4's estimate is 1.2-fold (0.06 log units) above it; the measured number falls inside the stated range.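

In this assay, trifluoromethyl in place of chloro on an aromatic carbon gave a 2.7-fold lower number from compound 3 to compound 4 (0.43 log units; beyond the scatter), so on this second core the number fell as it had on the first. Set side by side, the two steps agree in direction and in size: the same change on two cores in this assay, a 2.3-fold lower number (0.36 log units; beyond the scatter) from compound 1 to compound 2 and a 2.7-fold lower number (0.43 log units; beyond the scatter) from compound 3 to compound 4, 1.2-fold (0.06 log units) apart, within the scatter of two such steps This shows that, for these two pairs, the change carried from one core to the other with its size intact, but two pairs in a single assay on one cell line cannot show that it would carry to every core in the series, and they say nothing about why the number falls.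

The compounds shown leave open what other groups on the same aromatic carbon would do, for instance a methyl, a methoxy, a nitrile or an amine, as only chloro and trifluoromethyl appear there. Also open, on these data alone, is whether the same swap would give a step of this size on a third core, or whether the agreement seen here is limited to the core of compound 1 and the core of compound 3.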